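Cyclopropyl to 2,4-difluorophenyl on the aromatic nitrogen

The compounds below may be only part of what the source reports. "The series", "measured", "known", "first", "only" and "open" are said of these compounds alone.

Measured in a functional assay on V79 cells (Cricetulus griseus) for cytotoxicity, read by colony formation; on this read-out lower numbers stand for stronger inhibition and higher numbers for weaker inhibition:
Compound 1 `CC1(N)CCN(c2c(F)cc3c(=O)c(C(=O)O)cn(-c4ccc(F)cc4F)c3c2C(F)(F)F)C1` gives 18 ug/mL
Compound 2 `CC1CN(c2c(F)cc3c(=O)c(C(=O)O)cn(-c4ccc(F)cc4F)c3c2Cl)CCN1` gives > 500 ug/mL (a limit, not a number)
Compound 3 `CC1CN(c2c(F)cc3c(=O)c(C(=O)O)cn(C4CC4)c3c2C(F)(F)F)CCN1` gives 220 ug/mL

Compound 3 holds the higher of the two actual numbers in the set (220 ug/mL), and compound 1 holds the lower (18 ug/mL), a gap beyond the usual scatter. Compound 4 `CC1CN(c2c(F)cc3c(=O)c(C(=O)O)cn(-c4ccc(F)cc4F)c3c2C(F)(F)F)CCN1` has not yet been measured. It has 2,4-difluorophenyl in place of cyclopropyl on an aromatic nitrogen, on a site that is ortho to a fused ring and meta to a carboxy group.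

Within the data shown here, no pair of measured compounds shows this change alone, so the size of the step in this assay rests on thin ground. Compound 2 also carries 2,4-difluorophenyl and reads > 500 ug/mL as a limit of the assay. Compound 1 carries the same group and goes against any link to high numbers, with 18 ug/mL as its value.

A small move towards weaker inhibition is expected, with no step beyond the scatter. The estimated step of a 1.4-fold higher number from compound 3 to compound 4 (0.13 log units; within the scatter) is therefore modest and uncertain. In this assay the expected value for compound 4 is 300 ug/mL within an estimated range of 100 ug/mL to 800 ug/mL and a reading at the limit remains possible.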

Compound 4, half-maximal inhibitory concentration: > 500 ug/mL
Compound 4 ended at the assay's limit; the forecaster's own chance of this, stated with the estimate: 35%; middle value at least 1.6-fold (0.22 log units) from the limit.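

In this assay, among these compounds, the change now stands alone for the first time: 2,4-difluorophenyl in place of cyclopropyl on the aromatic nitrogen gives an at least 2.2-fold higher number from compound 3 to compound 4 (0.35 log units; beyond the scatter), a move towards weaker inhibition, while 3-methylpiperazin-1-yl in place of 3-amino-3-methylpyrrolidin-1-yl, with 2,4-difluorophenyl held constant, gives an at least 27-fold higher number from compound 1 to compound 4 (1.44 log units; beyond the scatter). So 2,4-difluorophenyl on this nitrogen does not fix the read-out on its own, since compound 1 carries it and stays far lower than compound 4, whose reading is a limit of the assay, as is that of compound 2, so the step between those two cannot be read. Both readable steps are only lower bounds on their true size because the reading of compound 4 stops at the top of the range: the limit of > 500 ug/mL in this assay, at which 2 of the 4 values shown sit.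

On these data alone, it remains open how far compound 4 lies past that limit, and whether cyclopropyl would also read lower than 2,4-difluorophenyl with 3-amino-3-methylpyrrolidin-1-yl on the core. As far as these compounds go, how an ethyl or a 4-fluorophenyl group on the aromatic nitrogen would compare with these two groups also stays open.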